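Methyl on the pyrazole nitrogen: from compound 1 to compound 4

The source may hold more compounds than are shown below. What is called first, only, known or untested is meant among the compounds shown, and "the series" means these compounds.

Measured so far in an assay on isolated protein for binding affinity to Leucine-rich repeat serine/threonine-protein kinase 2 (Homo sapiens), read by TR-FRET and LanthaScreen, with a stated time of 2 h; a lower number here means a stronger inhibitor, a higher number a weaker inhibitor:
compound 1 `C[C@@H]1CCCN1c1c(C#N)c2c(N)nc(Nc3cn[nH]c3)nc2n1C` gives 0.2 nM
compound 2 `Cn1c(-c2ccccc2)c(C#N)c2c(N)ncnc21` gives 30 nM
compound 3 `C[C@@H]1CCCN1c1[nH]c2ncnc(N)c2c1C#N` gives 4 nM

Compound 1 stands at the lowest of the three numbers in this assay. Compound 3 is the nearest to it, and that gap is already beyond the scatter; compound 2 lies furthest off, also beyond the scatter. Among the compounds with values here, no two measured compounds differ in only one place, so the series gives no measured step from which the size of a single change can be read.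

Compound 4 `C[C@@H]1CCCN1c1c(C#N)c2c(N)nc(Nc3cnn(C)c3)nc2n1C` has not yet been measured. It differs from compound 1 by methyl in place of hydrogen on an aromatic nitrogen. Within the data shown here, with no measured step of this kind available, the expectation rests on compound 1 alone. The step of a 2.0-fold higher number from compound 1 to compound 4 (0.30 log units; within the scatter) is expected to be small, toward a somewhat higher number, with a fair chance that it stays within the scatter. Compound 4 is estimated at 0.4 nM, with a range from 0.1 nM to 2 nM.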

Compound 4, inhibition constant: 0.1 nM
Compound 4: the middle estimate sits 4.0-fold (0.60 log units) above what was measured, within the range that was stated.
By their numbers in this assay, from the lowest: compounds 4 and 1 (each within the scatter of the next); then compound 3; then compound 2.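

In this assay, within the data shown here, methyl in place of hydrogen on the aromatic nitrogen of the 1H-pyrazol-4-yl group gives the first step that can be read at a single place (a 2.0-fold lower number from compound 1 to compound 4 (0.30 log units; within the scatter)). The hydrogen on this nitrogen is therefore not required for a value in this range, and the 1-methyl-1H-pyrazol-4-yl group serves as well as the 1H-pyrazol-4-yl group within the scatter. No measured property bears on this result, so no cause can be offered.

As far as these compounds go, only methyl has been seen on this nitrogen, so it remains open whether an ethyl group or a longer chain would leave the number within the scatter. The same question stands for a chain ending in an amine or a carboxylic acid.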